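The compounds below may be only part of what the source reports. "The series", "measured", "known", "first", "only" and "open" are said of these compounds alone.

Compound 1, `COc1cc(/C=C2\C(=O)Nc3ccc(Cl)cc32)ccc1OCCCN1CC(C)OC(C)C1`: in a functional assay on A549 cells (Homo sapiens) for cytotoxicity, read by MTT assay, with a stated time of 48 h (on this read-out higher numbers stand for weaker inhibition and lower numbers for stronger inhibition), compound 1 gives 6250 nM.
Compound 2, `COc1cc(/C=C2\C(=O)Nc3ccc(C)cc32)ccc1OCCCN1CC(C)OC(C)C1`: in this assay compound 2 reaches only a limit of the assay, > 20000 nM.
Compound 3, `COc1cc(/C=C2\C(=O)Nc3ccc(Cl)cc32)ccc1OCCCN1CCN(c2ncccc2C(F)(F)F)CC1`: in this assay compound 3 gives 9530 nM.

Compound 1 and compound 3 carry the same core; the difference between the two cores is not broken down here. Against compound 1, compound 3 stands at a value that is within the usual scatter, so the two cannot be ordered.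

Compound 2 differs from compound 1 in one place: methyl in place of chloro on an aromatic carbon. The step of an at least 3.2-fold higher number from compound 1 to compound 2 (0.50 log units; beyond the scatter) can only be given as a lower bound, since compound 2 sits at the limit of > 20000 nM in this assay, at which 1 of the 3 values shown sits.

The unmeasured compound 4, `COc1cc(/C=C2\C(=O)Nc3ccc(C)cc32)ccc1OCCCN1CCN(c2ncccc2C(F)(F)F)CC1`, differs from compound 3 in one place: methyl in place of chloro on an aromatic carbon. This is the same change as the one from compound 1 to compound 2, made on the same kind of position of the shared core, and it occurs twice among the compounds shown.

The step of a 3.1-fold higher number from compound 3 to compound 4 (0.50 log units; beyond the scatter) is the one expected here, and this expectation rests on the measured step of an at least 3.2-fold higher number from compound 1 to compound 2 (0.50 log units; beyond the scatter). Compound 4 is therefore expected to give about 30000 nM in this assay, with a range from 12000 nM to 80000 nM, and a real chance that only a limit is reported.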

Compound 4, half-maximal inhibitory concentration: > 20000 nM
Compound 4: a limit, no number; the forecaster's own chance of this, stated with the estimate: 65%; the middle value is on the limit's open side.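

In this assay compound 4 reaches only a limit of the assay, > 20000 nM, and not a number. Methyl in place of chloro on this aromatic carbon thus gives an at least 2.0-fold higher number from compound 3 to compound 4 (0.32 log units; beyond the scatter), so the change moves the read-out towards weaker inhibition on both cores: the same change on two cores in this assay, an at least 3.2-fold higher number (0.50 log units; beyond the scatter) from compound 1 to compound 2 and an at least 2.0-fold higher number (0.32 log units; beyond the scatter) from compound 3 to compound 4; the limit leaves it open whether they differ. The direction therefore carries from one core to the other in these two pairs, but the size cannot be carried over, since both steps are only bounds and neither shows how much weaker the methyl compound is or whether the core alters the effect: the limit of > 20000 nM in this assay, at which 2 of the 4 values shown sit.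

The compounds shown hold only chloro and methyl on this aromatic carbon, so it stays open how a fluoro, a methoxy or a nitrile group would read there on either core. As far as these compounds go, it also stays open whether a side chain ending in a primary amine or a carboxylic acid would bring a methyl compound back from the limit to a measurable number.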